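The compounds below may be only part of what the source reports. "The series", "measured", "known", "first", "only" and "open" are said of these compounds alone.

Measured compounds:
- compound 1, `CNC(=O)c1cc(Oc2ccc(NC(=O)c3nn(-c4cccc(F)c4)c(=O)cc3C)cc2F)ccn1`, gives 9540 nM in a functional assay on A549 cells (Homo sapiens) for cytotoxicity, read by MTT assay, with a stated time of 72 h; a higher number here means a weaker inhibitor, a lower number a stronger inhibitor
- compound 2, `CNC(=O)c1cc(Oc2ccc(NC(=O)c3nn(-c4ccc(C)cc4)c(=O)cc3C)cc2F)ccn1`, gives 11500 nM in this assay
- compound 3, `Cc1cc(=O)n(-c2cccc(F)c2)nc1C(=O)Nc1ccc(Oc2ncnc3ccsc23)cc1`, gives 9540 nM in this assay

Compounds 1 and 2 share a core and differ in one place: 4-methylphenyl in place of 3-fluorophenyl on an aromatic nitrogen. This change made a step of a 1.2-fold higher number from compound 1 to compound 2 (0.08 log units; within the scatter), so the two numbers lie within the usual scatter of each other and no order between them can be read.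

Compound 3 carries a different core from compound 1; how the two cores differ is not broken down here. In this assay compound 3 gives a number that stands level with compound 1 at the digits shown, and its gap to compound 2 is also within the scatter.

Compound 4, `Cc1ccc(-n2nc(C(=O)Nc3ccc(Oc4ncnc5ccsc45)cc3)c(C)cc2=O)cc1`, is not yet measured. It stands to compound 3 as compound 2 stands to compound 1, carrying the same change: 4-methylphenyl in place of 3-fluorophenyl on an aromatic nitrogen. Because the same change gave a 1.2-fold higher number from compound 1 to compound 2 (0.08 log units; within the scatter), the step from compound 3 to compound 4 is expected to be about as small, at a 1.2-fold higher number from compound 3 to compound 4 (0.06 log units; within the scatter). On that basis, and because compound 3 gives 9540 nM, compound 4 is estimated at 11000 nM in this assay, with the expected range running from 5000 nM to 25000 nM.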

Compound 4, half-maximal inhibitory concentration: 11500 nM
Estimate against measurement, compound 4: 1.0-fold (0.02 log units) below, and the stated range covers the measured number.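

In this assay, putting 4-methylphenyl in place of 3-fluorophenyl on the aromatic nitrogen gave a 1.2-fold higher number from compound 3 to compound 4 (0.08 log units; within the scatter), so no order can be read between these two compounds. Set beside the earlier step on the core of compound 1, the change reads the same on both cores, and the two steps cannot be told apart: the same change on two cores in this assay, a 1.2-fold higher number (0.08 log units; within the scatter) from compound 1 to compound 2 and a 1.2-fold higher number (0.08 log units; within the scatter) from compound 3 to compound 4, 1.0-fold (0.00 log units) apart, within the scatter of two such steps. Among the compounds shown here, this shows only that the swap left no readable mark on either core, which is a consistent null result across this one pair of cores; it does not show that the two groups are equivalent in general, that the same would hold on any further core, or that a change with a real effect would carry over, since neither step here rises above the scatter.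

The compounds shown leave open whether anything placed on that nitrogen can move the number beyond the scatter in this assay, since only these two substituted phenyl groups appear there. An amine or a carboxylic acid on the phenyl ring, or a short alkyl chain in place of the ring, would test this, and whether any such step would then match across the two cores also remains unanswered.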